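A few compounds are considered here, and "the series" means these few. Any claim that something is new, unique, unknown or untested is made for them only; others in the source may bear on it.

Compound 1, with the structure `CN(C)/C=C/C(=O)c1cc2ccccc2oc1=O`, and compound 2, with the structure `N=C(N)NS(=O)(=O)c1ccc(N/C=C\C(=O)c2cc3ccccc3oc2=O)cc1`, share a core and were both tested in a functional assay on T47D cells (Homo sapiens) for cytotoxicity, read by sulforhodamine B assay, with a stated time of 48 h; on this read-out lower numbers stand for stronger inhibition and higher numbers for weaker inhibition. In this assay compound 1 gives 147000 nM. In this assay compound 2 gives 87600 nM, the lower of the two numbers, though the two values lie within the usual scatter of each other, so no order between them can be read from this pair.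

Compound 3, with the structure `Cc1noc(NS(=O)(=O)c2ccc(N/C=C\C(=O)c3cc4ccccc4oc3=O)cc2)c1C`, has not yet been measured. Its change from compound 2 is a group of 7 heavy atoms (5 carbon, 1 nitrogen, 1 oxygen; one five-membered aromatic ring with 2 hetero atoms) in place of a group of 3 heavy atoms (1 carbon, 2 nitrogen; no ring), on a sulfonamide nitrogen. Among the compounds with values here, no measured pair shows what such a change does here, so the only guide is that both known compounds sit in a weak range. The step from compound 2 to compound 3 is expected to be small, a 1.2-fold lower number from compound 2 to compound 3 (0.07 log units; within the scatter), with no direction beyond the scatter favoured. Compound 3 is therefore estimated at 75000 nM, within a range from 25000 nM to 220000 nM.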

Compound 3, half-maximal inhibitory concentration: 68400 nM
Compound 3: middle estimate off by 1.1-fold (0.04 log units), on the high side; low and high end bracket the measured number.
By their numbers in this assay, from the lowest: compounds 3, 2 and 1 (each within the scatter of the next, the first and the last beyond it).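

In this assay, a 3,4-dimethyl-1,2-oxazol-5-yl group on the sulfonamide nitrogen, in place of the group without a ring carried by compound 2, gives a 1.3-fold lower number from compound 2 to compound 3 (0.11 log units; within the scatter). This first step at this position shows that a larger group with one five-membered aromatic ring, and with no hydrogen-bond donors, leaves the number within the scatter, so this pair gives no sign that the position responds to such a swap. No measurement at hand bears on why the step has this size.

Going by these compounds, it remains open whether any other group on this nitrogen, such as a plain phenyl ring, a small methyl or a longer chain ending in an amine or a carboxylic acid, would move the number beyond the scatter. A single step also cannot show whether the two methyl groups on the new ring matter.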